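This account rests on a few compounds, and the source may have more. Where it says the series, first, only, none or still open, it means among the compounds named here.

Compound 1 `CCOC(=O)c1sc(-c2ccc(C)cc2)nc1O` was tested in an assay on HEK293 cells for inhibition of transient receptor potential cation channel subfamily M member 8 (Homo sapiens), read by FLIPR, with stated times of 5 min and 3 min (a lower number here means a stronger inhibitor, a higher number a weaker inhibitor), where compound 1 gives 160 nM. Among the compounds with values here, that is the higher of the two numbers measured so far; compound 2 `O=C(c1sc(-c2ccccc2O)nc1O)N1CCCCO1` gives 81 nM in this assay, a gap that stays within the usual scatter, so the two stand level. Compound 3 `CCOC(=O)c1sc(-c2ccc(F)cc2)nc1O` differs from compound 1 in a single place: fluoro in place of methyl on an aromatic carbon. Within the data shown here, no measured pair shows this exact change, so no direction can be read off. The step of a 1.3-fold higher number from compound 1 to compound 3 (0.10 log units; within the scatter) is expected to stay within the scatter. Compound 3 is estimated at 200 nM, with a range from 80 nM to 500 nM.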

Compound 3, half-maximal inhibitory concentration: 80 nM
For compound 3 the middle estimate is 2.5-fold (0.40 log units) above the measured one, and the stated range covers the measured number.
By their numbers in this assay, from the lowest: compounds 3, 2 and 1 (each within the scatter of the next).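

Replacing methyl with fluoro on this aromatic carbon, para to a large group, gives a 2.0-fold lower number from compound 1 to compound 3 (0.30 log units; within the scatter) in this assay. This is the only single-place comparison shown, and it indicates that, in this assay, this position tolerates either group without a change beyond the scatter. Nothing measured here explains this outcome. Still open, as far as these compounds go, is whether an amine, a carboxylic acid or a longer chain at this position would also stay level. A single pair also cannot show how the same change would behave elsewhere on the ring.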